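A few compounds are considered here, and "the series" means these few. Any claim that something is new, unique, unknown or untested is made for them only; others in the source may bear on it.

Of the compounds shown here, three built on one shared core have been tested in an ADME assay on HepG2 cells (Homo sapiens) for cytotoxicity, read by luminescence, CellTiter-Glo and ATP content, with a stated time of 72 h; on this read-out lower numbers stand for an effect already at smaller amounts and higher numbers for an effect only at larger amounts of compound. Compound 1, `COc1ccc(F)cc1CNCCCNc1ccnc2cc(Cc3cc(C)cc(C)c3)ccc12`, gives 940 nM. Compound 2, `c1ccc(Oc2ccc3c(NCCCNCc4ccco4)ccnc3c2)cc1`, gives 15200 nM, and compound 3, `COc1cccc(CNCCCNc2ccnc3cc(Oc4ccc(F)cc4)ccc23)c1O`, gives 11000 nM. Compound 1 therefore has the lowest number of the three; its gap to compound 3 and its gap to compound 2 both lie beyond the usual scatter, so compound 1 shows an effect on these liver cells at smaller amounts than either of the other two.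

Compound 4, `COc1ccc(F)cc1CNCCCNc1ccnc2cc(Cc3ccc(F)cc3)ccc12`, has not yet been measured in this assay. It differs from compound 1 in a single place: 4-fluorophenyl in place of 3,5-dimethylphenyl on a saturated chain carbon bound to an aromatic carbon. For the measured compounds named here, no pair of measured compounds isolates this particular change, and compounds 2 and 3 differ from compound 1 in several places at once, so they offer no direct guide to it. A modest rise in the number, near the edge of the scatter, is expected for compound 4, as a 2.1-fold higher number from compound 1 to compound 4 (0.33 log units; beyond the scatter). Compound 4 is accordingly estimated at 2000 nM, with a likely range from 700 nM to 6000 nM.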

Compound 4, half-maximal effective concentration: 3530 nM
For compound 4 the middle estimate is 1.8-fold (0.25 log units) below the measured one, within the range that was stated.
By their numbers in this assay, from the lowest: compound 1; then compound 4; then compounds 3 and 2 (each within the scatter of the next).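

In this assay, replacing 3,5-dimethylphenyl with 4-fluorophenyl on a saturated chain carbon bound to an aromatic carbon gives a 3.8-fold higher number from compound 1 to compound 4 (0.57 log units; beyond the scatter). For the compounds shown here, this is the first pair here that differs in one place, and it shows that the number responds to this change, with a modest step beyond the scatter. Both groups are six-membered aromatic rings of carbon only with no net charge, so the step comes with a change in what the ring carries, and nothing measured here gives a reason for it.

On these data alone, the methyl groups leave and the fluorine enters in the same step, so their separate shares stay unknown. A plain phenyl group or a 3,5-difluorophenyl group at this place would help to separate them.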